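The source may hold more compounds than are shown below. What is called first, only, known or untested is meant among the compounds shown, and "the series" means these compounds.

Working notes on the series. The shared core, a trimethoxyphenyl nitrogen bearing a substituted benzyl group, is carried by compound 1 `COc1ccc(CNc2cc(OC)c(OC)c(OC)c2)cc1Cl`, compound 3 `COc1ccc(CNc2cc(OC)c(OC)c(OC)c2)cc1` and compound 2 `CC/C=C/C(=O)N(Cc1ccc(OC)c(O)c1)c1cc(OC)c(OC)c(OC)c1`. In a functional assay on MGC-803 cells (Homo sapiens) for inhibition, read by MTT assay, with a stated time of 48 h (on this read-out higher numbers stand for weaker inhibition and lower numbers for stronger inhibition), compound 1 gives 46200 nM, compound 3 gives 11400 nM and compound 2 gives 58 nM, the lowest of the three numbers. Among the measured compounds shown here, the one single-point step recorded is a 4.1-fold lower number from compound 1 to compound 3 (0.61 log units; beyond the scatter), which concerns the benzyl ring and not the acyl group.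

Compound 4 `COc1ccc(CN(C(=O)C2CC2)c2cc(OC)c(OC)c(OC)c2)cc1O` differs from compound 2 by cyclopropyl in place of but-1-en-1-yl on a carbonyl carbon. For the measured compounds named here, no measured step touches the carbonyl substituent, so there is no direct precedent; the amide of compound 2 stands far below the two secondary amines. The number for compound 4 is therefore expected close to compound 2, a 1.7-fold higher number from compound 2 to compound 4 (0.24 log units; within the scatter), within the scatter. Compound 4 is estimated at 100 nM, between 30 nM and 400 nM.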

Compound 4, half-maximal inhibitory concentration: 59 nM
For compound 4 the middle estimate is 1.7-fold (0.23 log units) above the measured one, within the range that was stated.
By their numbers in this assay, from the lowest: compounds 2 and 4 (each within the scatter of the next); then compound 3; then compound 1.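

Among the compounds shown here, on a carbonyl carbon bound to the amide-type nitrogen, cyclopropyl in place of but-1-en-1-yl gives a 1.0-fold higher number from compound 2 to compound 4 (0.01 log units; within the scatter) in this assay, the first measured step at this position. The position thus takes either a three-membered ring of carbon only or an open chain with a double bond, and the two numbers cannot be told apart. No measurement at hand bears on the cause of this match. Open, as far as these compounds go, is whether an amine, a carboxylic acid or a longer chain on this carbonyl carbon would keep the number in the same range.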